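Removing One Chloro From a Dichlorinated Purine Core

This account rests on a few compounds, and the source may have more. Where it says the series, first, only, none or still open, it means among the compounds named here.

Measured so far:
compound 1 `ClCc1cccc(Cn2cnc3c(Cl)ncnc32)c1`: 89100 nM
compound 2 `ClCc1ccc(Cn2cnc3nc(Cl)nc(Cl)c32)cc1`: 5620 nM
compound 3 `ClCc1cccc(Cn2cnc3c(Cl)nc(Cl)nc32)c1`: 5880 nM

These three compounds were tested in a functional assay on UO-31 cells (Homo sapiens) for cytotoxicity, read by sulforhodamine B assay, with a stated time of 48 h; a lower number here means that less compound is tolerated, a higher number that more compound is tolerated. Compound 2 and compound 3 give numbers within the scatter of each other; the difference between their two cores is not broken down here. Compound 1 differs from compound 3 by hydrogen in place of chloro on an aromatic carbon, and this change gave a 15-fold higher number from compound 3 to compound 1 (1.18 log units; beyond the scatter), so compound 1 is tolerated far more than the others.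

Compound 4 `ClCc1ccc(Cn2cnc3ncnc(Cl)c32)cc1` has not yet been measured in this assay. It differs from compound 2 by hydrogen in place of chloro on an aromatic carbon, the same change, at the same kind of place, as from compound 3 to compound 1. On that single precedent, compound 4 is expected to follow with a 14-fold higher number from compound 2 to compound 4 (1.15 log units; beyond the scatter). Compound 4 is therefore estimated at 80000 nM, with a likely range from 30000 nM to 200000 nM.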

Compound 4, concentration lethal to 50% of the cells: > 100000 nM
Compound 4 gave a limit, no number; the forecaster's own chance of this, stated with the estimate: 10%; at least 1.2-fold (0.09 log units) between middle value and limit.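

In this assay compound 4 gives > 100000 nM as a limit of the assay, not a number. Replacing the chloro with hydrogen gives an at least 17-fold higher number from compound 2 to compound 4 (1.25 log units; beyond the scatter) on this core. The change therefore carries across the two cores shown in the same direction and is large on both, but how closely its size matches from one core to the other remains unsettled: the same change on two cores in this assay, a 15-fold higher number (1.18 log units; beyond the scatter) from compound 3 to compound 1 and an at least 17-fold higher number (1.25 log units; beyond the scatter) from compound 2 to compound 4; the limit leaves it open whether they differ

The compounds shown leave open whether an amine or a methoxy group at that same place would give a number closer to that of the chloro compounds or to that of the hydrogen compounds. They also leave open whether the change would carry over to cores beyond these two.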